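Methoxy added to a methyl-bearing cinnamoyl amide

The source may hold more compounds than are shown below. What is called first, only, known or untested is meant among the compounds shown, and "the series" means these compounds.

Compound 1 `COc1ccc(/C=C/C(=O)Nc2nc3ccc([N+](=O)[O-])cc3s2)cc1` gives 315 umol/kg
Compound 2 `O=C(/C=C/c1ccccc1)Nc1nc2ccc([N+](=O)[O-])cc2s1` gives 485 umol/kg
Compound 3 `Cc1ccc2nc(NC(=O)/C=C/c3ccccc3)sc2c1` gives 380 umol/kg

In a functional assay on the whole organism (Hindlimb, strain albino) with Mus musculus as the target, in the maximal electroshock model, with a stated time of 0.5 h (a higher number here means that more compound is needed for the effect, a lower number that less compound is needed), compound 3 gives 380 umol/kg and lies within the scatter of both compound 1 and compound 2, so nothing sets it apart from either. Compound 4 `COc1ccc(/C=C/C(=O)Nc2nc3ccc(C)cc3s2)cc1` is compound 3 with a single change, (methoxy in place of hydrogen on an aromatic carbon), that is, methoxy in place of hydrogen on an aromatic carbon, para to a large group.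

The nearest evidence is the same exchange read in reverse in the nitro series, where the loss of methoxy gives a 1.5-fold higher number from compound 1 to compound 2 (0.19 log units; within the scatter). The step of a 1.3-fold lower number from compound 2 to compound 3 (0.11 log units; within the scatter) also stays within the scatter, and it concerns the other substituent. Among the compounds with values here, only this one pair speaks to the methoxy group, so a small move towards a lower number in this assay is expected, not one clearly beyond the scatter. The expected step is a 1.4-fold lower number from compound 3 to compound 4 (0.16 log units; within the scatter). For compound 4 the estimated value is 265 umol/kg, with an expected range from 140 umol/kg to 490 umol/kg.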

Compound 4, dose for half-maximal effect: 209 umol/kg
Beside the measured number, compound 4's estimate is 1.3-fold (0.10 log units) above it; measured number inside the range.
By their numbers in this assay, from the lowest: compounds 4, 1, 3 and 2 (each within the scatter of the next, the first and the last beyond it).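

In this assay, methoxy in place of hydrogen on the aromatic carbon now has a second reading, on the methyl-bearing core, which gives a 1.8-fold lower number from compound 3 to compound 4 (0.26 log units; within the scatter). The change points the same way on both cores, and each step stays within the scatter: the same change on two cores in this assay, a 1.5-fold higher number (0.19 log units; within the scatter) from compound 1 to compound 2 and a 1.8-fold higher number (0.26 log units; within the scatter) from compound 4 to compound 3, 1.2-fold (0.07 log units) apart, within the scatter of two such steps

Methyl in place of nitro also now reads twice, with a 1.5-fold lower number from compound 1 to compound 4 (0.18 log units; within the scatter), and again the two readings agree: the same change on two cores in this assay, a 1.3-fold lower number (0.11 log units; within the scatter) from compound 2 to compound 3 and a 1.5-fold lower number (0.18 log units; within the scatter) from compound 1 to compound 4, 1.2-fold (0.07 log units) apart, within the scatter of two such steps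

Each single step shown lies within the scatter, so it remains open whether either exchange alone truly shifts the dose needed. As far as these compounds go, it is also open how an amine, a hydroxyl group or a longer chain such as ethoxy would read on this aromatic carbon.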